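The compounds below may be only part of what the source reports. "The series", "measured", "known", "first", "only" and "open" are said of these compounds alone.

Measured so far:
- compound 1, `C=C(C)n1c(=O)n(Cc2nc3ccccc3n2CCCC#N)c2cccnc21`: 150000 nM
- compound 2, `N#CCCCn1c(Cn2c(=O)n(Cc3ccc(C#N)cc3)c3ccncc32)nc2ccccc21`: 36800 nM

Both were tested in an ADME assay on HEp-2 cells (Homo sapiens) for cytotoxicity; on this read-out higher numbers stand for lower toxicity in this test and lower numbers for higher toxicity in this test. Compound 1 gives 150000 nM there, and compound 2 gives 36800 nM. Among the compounds with values here, of the two numbers, compound 2 has the lower one; its only neighbour, compound 1, sits at a higher number, and that gap lies beyond the usual scatter of the test.

Compound 3, `N#CCCCn1c(Cn2c(=O)n(CC3CC3)c3ccncc32)nc2ccccc21`, has not yet been measured in this assay. It differs from compound 2 in a single place: cyclopropyl in place of 4-cyanophenyl on a saturated chain carbon bound to an aromatic nitrogen. Within the data shown here, no pair of measured compounds shows this particular change, so its size cannot be read from the data at hand, and the expectation rests only on compound 2 and on the nature of the replacement. The expected step is a 1.6-fold higher number from compound 2 to compound 3 (0.21 log units; within the scatter), modest and toward a higher number, though a result within the scatter of compound 2 would not be surprising. Compound 3 is estimated at 60000 nM, with a range from 20000 nM to 180000 nM.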

Compound 3, half-maximal cytotoxic concentration: 96500 nM
Compound 3: middle estimate off by 1.6-fold (0.21 log units), on the low side; low and high end bracket the measured number.
By their numbers in this assay, from the lowest: compound 2; then compounds 3 and 1 (each within the scatter of the next).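

In this assay, the replacement of 4-cyanophenyl by cyclopropyl on a saturated chain carbon bound to an aromatic nitrogen gives a 2.6-fold higher number from compound 2 to compound 3 (0.42 log units; beyond the scatter). Within the data shown here, this is the first single-place comparison, and it shows that this position is not silent in this test: with the rest of the structure unchanged, 4-cyanobenzyl and cyclopropylmethyl give numbers that lie apart, and the cyclopropylmethyl compound has the higher number, which stands for lower toxicity in this test. Nothing at hand gives a reason for this difference.

The change removes the six-membered aromatic ring and the nitrile together, so the compounds shown cannot say how much of the step belongs to either one, and a plain benzyl group at the same place would be needed to separate them. Going by these compounds, it also remains open how far the number would move with a simple methyl, a longer chain such as n-butyl, or a group carrying an amine or a carboxylic acid, and whether the same step would hold on the core of compound 1.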